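A Small Change on the Shared Core

A few compounds are considered here, and "the series" means these few. Any claim that something is new, unique, unknown or untested is made for them only; others in the source may bear on it.

Compound 1, `C[S+]([O-])/C=C/c1cc(=O)c2ccccc2o1`: 8000 nM
Compound 2, `CCCCCOc1ccc2oc(/C=C/[S+](C)[O-])cc(=O)c2c1`: 6600 nM
Compound 3, `CCCCC(=O)Oc1ccc2oc(/C=C/[S+](C)[O-])cc(=O)c2c1`: 6700 nM

In a functional assay on DLD-1 cells (Homo sapiens) for cytotoxicity, with a stated time of 48 h (on this read-out higher numbers stand for weaker inhibition and lower numbers for stronger inhibition), compound 1 gives the highest of the three numbers, yet the steps of a 1.2-fold lower number from compound 1 to compound 2 (0.08 log units; within the scatter) and a 1.2-fold lower number from compound 1 to compound 3 (0.08 log units; within the scatter) both lie within the scatter, so no order among the three can be claimed. Compound 4, `Cc1ccc2c(=O)cc(/C=C/[S+](C)[O-])oc2c1`, differs from compound 1 by methyl in place of hydrogen on an aromatic carbon. The steps measured so far added pentyloxy or (butylcarbonyl)oxy on an aromatic carbon and moved the number little, and the step of a 1.0-fold higher number from compound 2 to compound 3 (0.01 log units; within the scatter) also stays within the scatter. Among the measured compounds shown here, no measured step puts a methyl at the place of compound 4, so the only guide is that small additions to the shared core have changed little. Compound 4 is therefore expected to show no change at the digits printed from compound 1 to compound 4 (within the scatter), nothing beyond the scatter. The estimate for compound 4 is 8000 nM, within 4000 nM to 16000 nM.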

Compound 4, half-maximal inhibitory concentration: 7000 nM
The estimate for compound 4 lay 1.1-fold (0.06 log units) above the measured number, and the stated range covers the measured number.
By their numbers in this assay, from the lowest: compounds 2, 3, 4 and 1 (each within the scatter of the next).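

In this assay, methyl in place of hydrogen on this aromatic carbon, meta to a fused ring and para to a fused ring, gives a 1.1-fold lower number from compound 1 to compound 4 (0.06 log units; within the scatter). This adds a site on the shared core, one carrying a group of a single carbon, where the change stays within the scatter, as the pentyloxy and (butylcarbonyl)oxy steps also did. Nothing available explains this result. From the compounds shown here alone, whether an amine, a carboxylic acid or a longer chain at this carbon would move the number beyond the scatter remains open.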